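A few compounds are considered here, and "the series" means these few. Any claim that something is new, unique, unknown or untested is made for them only; others in the source may bear on it.

Of the compounds shown here, three built on a shared core have so far been tested in a functional assay on A549 cells (Homo sapiens) for cytotoxicity, read by sulforhodamine B assay, with a stated time of 48 h; a higher number here means a weaker inhibitor, a lower number a stronger inhibitor. Compound 1 `COc1ccc2c(c1)c(/C=C1/C(=O)Nc3ccc(F)cc31)cn2Cc1cn([C@@H]2O[C@H](COC(C)=O)[C@@H](OC(C)=O)[C@H](OC(C)=O)[C@H]2OC(C)=O)nn1` gives only a limit there, > 200000 nM, a value that marks the edge of the assay rather than a number (the limit of > 200000 nM in this assay, at which 1 of the 3 values shown sits). Compound 2 `COc1ccc(/C=C2\C(=O)N(Cc3cn([C@@H]4O[C@H](COC(C)=O)[C@@H](OC(C)=O)[C@H](OC(C)=O)[C@H]4OC(C)=O)nn3)c3ccccc32)cc1OC` gives 23300 nM in this assay. Compound 3 `CC(=O)OC[C@H]1O[C@@H](n2cc(CN3C(=O)/C(=C/c4ccc5ccccc5c4)c4ccccc43)nn2)[C@H](OC(C)=O)[C@@H](OC(C)=O)[C@@H]1OC(C)=O` gives 30900 nM. Compound 2 thus holds one end of the two numbers available, but compound 3 lies within the scatter of it, so the two cannot be told apart. Compound 4 `CC(=O)OC[C@H]1O[C@@H](n2cc(CN3C(=O)/C(=C\c4ccco4)c4ccccc43)nn2)[C@H](OC(C)=O)[C@@H](OC(C)=O)[C@@H]1OC(C)=O` has not yet been measured. It differs from compound 2 in a single place: furan-2-yl in place of 3,4-dimethoxyphenyl on a double-bonded chain carbon bound to a double-bonded ring carbon. For the measured compounds named here, no step between measured compounds touches this position, so the data give no gauge of how large such a swap might be, nor in which direction it runs. For compound 4 the expected step is a 1.7-fold higher number from compound 2 to compound 4 (0.23 log units; within the scatter), a modest shift toward a somewhat higher number that need not clear the scatter. Compound 4 is therefore estimated at 40000 nM, with a range from 10000 nM to 200000 nM.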

Compound 4, half-maximal inhibitory concentration: 41100 nM
Beside the measured number, compound 4's estimate is 1.0-fold (0.01 log units) below it, and the stated range covers the measured number.
By their numbers in this assay, from the lowest: compounds 2, 3 and 4 (each within the scatter of the next). At a limit, above all of these: compound 1.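

For the compounds shown here, the one step at this position in this assay is a 1.8-fold higher number from compound 2 to compound 4 (0.25 log units; within the scatter). It shows that this place, a double-bonded chain carbon bound to a double-bonded ring carbon, can take furan-2-yl, a five-membered aromatic ring with 5 heavy atoms, in place of 3,4-dimethoxyphenyl, a six-membered aromatic ring with 10 heavy atoms, without a change that can be told from the scatter. Nothing measured here gives a cause for this step.

The compounds shown leave open whether a cyclohexyl ring, or a phenyl ring carrying an amine or a carboxylic acid, would move the number beyond the scatter at this place. One pair also cannot show whether the same swap would stay within the scatter with other substituents on the shared core.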